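This account rests on a few compounds, and the source may have more. Where it says the series, first, only, none or still open, it means among the compounds named here.

Working notes on the series. Compound 1 `Oc1ccccc1CNc1ccc(-c2cccc(F)c2)cc1` and compound 2 `Cc1cccc(-c2ccc(NCc3ccccc3O)cc2)c1` share one core; compound 3 `Oc1ccccc1CNc1ccc(-c2ccccc2)c(F)c1` and compound 4 `Cc1cc(NCc2ccccc2O)ccc1-c1ccccc1` share another, and the difference between the two cores is not broken down here. In a functional assay on Jurkat cells (Homo sapiens) for activation, with a stated time of 24 h (a higher number here means that more compound is needed for the effect, a lower number that less compound is needed), compound 1 gives 2020 nM, compound 2 gives 9190 nM, and compound 3 gives 2850 nM. The change from compound 1 to compound 2, (methyl in place of fluoro on an aromatic carbon), made a step of a 4.5-fold higher number from compound 1 to compound 2 (0.66 log units; beyond the scatter). The change from compound 3 to compound 4, (methyl in place of fluoro on an aromatic carbon), is the same kind of change, but the place differs: in compound 1 the site is meta to a large group, in compound 3 it is ortho to a phenyl group and meta to a group of 9 heavy atoms. For the measured compounds named here, because the only measured instance is a 4.5-fold higher number from compound 1 to compound 2 (0.66 log units; beyond the scatter), a step of about a 3.2-fold higher number from compound 3 to compound 4 (0.50 log units; beyond the scatter) is expected for compound 4, with some allowance for the different surroundings. Compound 4 is therefore estimated at 9000 nM, with an expected range from 3000 nM to 30000 nM.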

Compound 4, half-maximal effective concentration: 8610 nM
Beside the measured number, compound 4's estimate is 1.0-fold (0.02 log units) above it; the range from low to high includes it.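

In this assay, methyl in place of fluoro on an aromatic carbon again goes with a higher number, here a 3.0-fold higher number from compound 3 to compound 4 (0.48 log units; beyond the scatter) on the core of compound 3. The two steps agree in direction and do not differ in size beyond the scatter: the same change on two cores in this assay, a 4.5-fold higher number (0.66 log units; beyond the scatter) from compound 1 to compound 2 and a 3.0-fold higher number (0.48 log units; beyond the scatter) from compound 3 to compound 4, 1.5-fold (0.18 log units) apart, within the scatter of two such steps. For the compounds shown here, this supports carrying the change between these two cores and their differing sites in this one assay, but with only two pairs it sets no rule for other cores or sites and gives no explanation for the step.

The compounds shown leave open how chloro, methoxy or a nitrile would compare with fluoro and methyl at these sites. They also leave open whether an amine or a carboxylic acid there would follow the same trend.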